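Trading a difluorophenyl for a hydroxyphenyl on a shared core

The source may hold more compounds than are shown below. What is called first, only, known or untested is meant among the compounds shown, and "the series" means these compounds.

Compound 1 `CCN(CC)CCCn1c(=O)c(=Cc2ccc(F)c(F)c2)s/c1=C1\C(=O)Nc2ccc(F)cc21` gives 640 nM in a functional assay on HT-29 cells (Homo sapiens) for inhibition, read by MTT assay, with a stated time of 72 h; on this read-out lower numbers stand for stronger inhibition and higher numbers for weaker inhibition.
Compound 2 `COc1ccc(C=c2s/c(=C3\C(=O)Nc4cc(F)ccc43)n(CCN(C)C)c2=O)cc1` gives 2300 nM in this assay.
Compound 3 `CN(C)CCn1c(=O)c(=Cc2ccc(F)c(F)c2)s/c1=C1\C(=O)Nc2ccc(F)cc21` gives 3090 nM in this assay.

Compound 3 has the highest number of the three. Its nearest neighbour is compound 2, whose value lies within the scatter of it, so no order between them can be read; compound 1 is the furthest, and the step of a 4.8-fold higher number from compound 1 to compound 3 (0.68 log units; beyond the scatter) lies beyond the scatter.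

Compound 4 `CN(C)CCn1c(=O)c(=Cc2ccc(O)cc2)s/c1=C1\C(=O)Nc2ccc(F)cc21` is not yet measured. It differs from compound 3 in one place: 4-hydroxyphenyl in place of 3,4-difluorophenyl on a double-bonded chain carbon bound to an aromatic carbon. Going by the values given here, none of the measured steps changes this position while holding everything else fixed. Compound 2 carries a different aryl group from compound 3 but also differs from it in a second place, and its value sits within the scatter of compound 3, which gives no sign of a large effect from the aryl group alone. A step of a 1.2-fold lower number from compound 3 to compound 4 (0.09 log units; within the scatter) is therefore expected, with compound 4 estimated at 2500 nM, and a range from 800 nM to 8000 nM is expected.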

Compound 4, half-maximal inhibitory concentration: 1480 nM
Beside the measured number, compound 4's estimate is 1.7-fold (0.23 log units) above it; measured number inside the range.
By their numbers in this assay, from the lowest: compound 1; then compounds 4, 2 and 3 (each within the scatter of the next, the first and the last beyond it).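

Going by these compounds alone, with everything else held fixed, 4-hydroxyphenyl in place of 3,4-difluorophenyl on a double-bonded chain carbon bound to an aromatic carbon gives a 2.1-fold lower number from compound 3 to compound 4 (0.32 log units; beyond the scatter) in this assay, the first reading of this position on its own. Within the data shown here, the step is modest but beyond the scatter, so the aryl group here does move the number, which the earlier compounds could not show. The 4-hydroxyphenyl carries a hydrogen-bond donor and acceptor that the 3,4-difluorophenyl lacks, but no measurement shown here accounts for the change.

This single pair leaves open whether the same exchange would give a similar step on the (diethylamino)methyl chain of compound 1. It also leaves open how an amine or a carboxylic acid in place of the hydroxyl would read.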